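Replacing 4-fluorophenyl with 2-methoxyphenyl

The compounds below may be only part of what the source reports. "The series", "measured", "known", "first", "only" and "open" are said of these compounds alone.

In a functional assay on HL-60 cells (Homo sapiens) for antiproliferative activity, read by MTT assay, with a stated time of 72 h (on this read-out lower numbers stand for stronger inhibition and higher numbers for weaker inhibition), compound 1 `COc1cc(C(=O)c2sc3ccccc3c2-c2ccccc2)cc(OC)c1OC` gives 1700 nM while compound 2 `COc1cc(C(=O)c2sc3ccccc3c2-c2ccc(F)cc2)cc(OC)c1OC` gives 3200 nM and compound 3 `COc1cc(C(=O)c2sc3ccccc3c2-c2ccc(SC)cc2)cc(OC)c1OC` gives 1300 nM on the same scale. Compound 2 has one clear gap among these numbers, namely a 2.5-fold lower number from compound 2 to compound 3 (0.39 log units; beyond the scatter) whereas a 1.9-fold higher number from compound 1 to compound 2 (0.27 log units; within the scatter) and a 1.3-fold lower number from compound 1 to compound 3 (0.12 log units; within the scatter) show no clear separation. Compound 4 `COc1ccccc1-c1c(C(=O)c2cc(OC)c(OC)c(OC)c2)sc2ccccc12` carries 2-methoxyphenyl in place of 4-fluorophenyl on an aromatic carbon. Among the measured compounds shown here, no measured step tests this group, but even the largest step a 2.5-fold lower number from compound 2 to compound 3 (0.39 log units; beyond the scatter) was only modest, so a slight move to a lower number, not beyond the scatter, is expected. In this assay the estimated step is a 1.6-fold lower number from compound 2 to compound 4 (0.20 log units; within the scatter) and no larger shift is expected. Compound 4 is estimated at 2000 nM with a range from 600 nM to 6000 nM as its likely span.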

Compound 4, half-maximal inhibitory concentration: 2900 nM
Compound 4: the middle estimate sits 1.5-fold (0.16 log units) below what was measured; measured number inside the range.
By their numbers in this assay, from the lowest: compounds 3, 1, 4 and 2 (each within the scatter of the next, the first and the last beyond it).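

In this assay, 2-methoxyphenyl and 4-fluorophenyl cannot be told apart at this position, with a 1.1-fold lower number from compound 2 to compound 4 (0.04 log units; within the scatter), and methoxy against hydrogen shows no clear separation either, with a 1.7-fold higher number from compound 1 to compound 4 (0.23 log units; within the scatter). Only the comparison with 4-(methylsulfanyl)phenyl separates, modestly, with a 2.2-fold higher number from compound 3 to compound 4 (0.35 log units; beyond the scatter). Nothing available explains that gap.

The compounds shown leave open whether a group of another kind on this phenyl ring, such as an amine or a carboxylic acid, would shift the number further.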